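Removing the para methoxy from the benzyl arm

The compounds below may be only part of what the source reports. "The series", "measured", "known", "first", "only" and "open" are said of these compounds alone.

Compound 2 `COc1ccc(CC2CCCCN2C(=O)n2ncc(C(O)(c3ccc(F)cc3)c3ccc(F)cc3)n2)cc1` is measured in an assay on isolated protein for inhibition of Monoacylglycerol lipase ABHD6 (Homo sapiens), read by fluorescence (a lower number here means a stronger inhibitor, a higher number a weaker inhibitor), at 251 nM. Among the three compounds with numbers, compound 2 stands second highest: its nearest neighbour is compound 1 `COc1cccc(CC2CCCCN2C(=O)n2ncc(C(O)(c3ccc(F)cc3)c3ccc(F)cc3)n2)c1`, which gives 158 nM, and the move a 1.6-fold higher number from compound 1 to compound 2 (0.20 log units; within the scatter) lies within the scatter. The furthest is compound 3 `O=C(N1CCCCC1Cc1ccccc1)n1ncc(C(O)(C2CCCCC2)C2CCCCC2)n1`, which gives 7940 nM, a much higher number.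

Compound 4 `O=C(N1CCCCC1Cc1ccccc1)n1ncc(C(O)(c2ccc(F)cc2)c2ccc(F)cc2)n1` differs from compound 2 in one place: hydrogen in place of methoxy on an aromatic carbon. Among the compounds with values here, only one measured step bears on this change, and only loosely: the shift of the methoxy group between two positions, a 1.6-fold higher number from compound 1 to compound 2 (0.20 log units; within the scatter), moved the number by less than the scatter. Within the data shown here, no measured pair removes the methoxy group altogether. Compound 3 shares the unsubstituted benzyl of compound 4 but also carries two cyclohexyl groups in place of two 4-fluorophenyl groups, so its high number cannot be laid to the benzyl alone. The expected step of a 1.1-fold higher number from compound 2 to compound 4 (0.05 log units; within the scatter) is therefore small, with a slight lean toward a higher number. Compound 4 is estimated at 280 nM, with a range from 110 nM to 700 nM.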

Compound 4, half-maximal inhibitory concentration: 25.1 nM
Estimate against measurement, compound 4: 11-fold (1.05 log units) above; measured number outside the range, below it.
By their numbers in this assay, from the lowest: compound 4; then compounds 1 and 2 (each within the scatter of the next); then compound 3.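

In this assay, taking the methoxy off the benzyl arm counts for far more than moving it: the step of a 10-fold lower number from compound 2 to compound 4 (1.00 log units; beyond the scatter) and the step of a 6.3-fold lower number from compound 1 to compound 4 (0.80 log units; beyond the scatter) both lie beyond the scatter, while the shift between the two methoxy positions, a 1.6-fold higher number from compound 1 to compound 2 (0.20 log units; within the scatter), stays within it. Within the data shown here, the near match of compound 1 and compound 2 therefore showed only that the two methoxy compounds read alike, and it gave no guide to the unsubstituted benzyl, which reads lower than either. Nothing among the data offers an explanation for the size of this step.

From the compounds shown here alone, it remains open whether a small replacement on this aromatic carbon, such as fluorine, a hydroxyl or an amine, would keep the lower number. Also open, going by these compounds, is whether the gain from losing the methoxy would hold alongside the two cyclohexyl groups of compound 3.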